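Cytotoxicity notes on the shared core: step to compound 4

A few compounds are considered here, and "the series" means these few. Any claim that something is new, unique, unknown or untested is made for them only; others in the source may bear on it.

Compound 3 `Cc1ccccc1-c1ccc(Cn2cncc2CNc2ccc(-c3nc4ccccc4s3)c(-c3ccccc3)c2)cc1` has been measured in a toxicity assay on NIH3T3 cells (Mus musculus) for cytotoxicity, read by resazurin assay (a lower number here means that less compound is needed, a higher number that more compound is needed for the effect), where compound 3 gives only a limit, > 1000 nM. Compound 2 `CC(C)c1ccc(Cn2cncc2CNc2ccc(-c3nc4ccccc4s3)c(-c3ccccc3)c2)cc1` likewise gives only a limit in this assay, > 1000 nM. Compound 1 `COC(=O)c1ccc(NCc2cncn2Cc2ccccc2C(C)(C)C)cc1-c1ccccc1` has no result in this assay, "not determined" (no result reported). Going by the values given here, the one measured step, a step that the two limits leave unreadable from compound 2 to compound 3, is thus unreadable, and the only evidence on the measured values is the limit of > 1000 nM in this assay, at which 2 of the 3 values shown sit. Compound 4 `CS(=O)(=O)c1ccc(Cn2cncc2CNc2ccc(-c3nc4ccccc4s3)c(-c3ccccc3)c2)cc1` differs from compound 3 by methylsulfonyl in place of 2-methylphenyl on an aromatic carbon. Among the compounds with values here, no measured step bears on this change, so no direction can be read from the series. Compound 4 is therefore expected to stay close to the same limit, with an estimated step that the limit leaves unreadable from compound 3 to compound 4. For compound 4 the estimate in this assay is 2000 nM, expected to fall between 1000 nM and 8000 nM.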

Compound 4, half-maximal effective concentration: > 1000 nM
Compound 4: no number, only a limit; the forecaster's own chance of this, stated with the estimate: 80%; the middle value is on the limit's open side.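

Going by these compounds alone, compound 2, compound 3 and compound 4 each give only a limit in this assay, so no step among them can be read. The compounds shown leave open whether isopropyl, 2-methylphenyl and methylsulfonyl differ at all in this assay on the shared core.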